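A Thiophene Swapped for a Sulfur-Linked Phenyl Group

A few compounds are considered here, and "the series" means these few. Any claim that something is new, unique, unknown or untested is made for them only; others in the source may bear on it.

Of the compounds shown here, three sharing one core have been measured in an assay for inhibition of Thromboxane-A synthase (Homo sapiens), using microsomes; a lower number here means a stronger inhibitor, a higher number a weaker inhibitor. Compound 1 `O=C(O)CC/C=C\CC1COC(c2ccccc2Cl)OC1c1cccnc1` gives 48 nM, and compound 2 `O=C(O)CC/C=C\CC1COC(c2ccc(Cl)cc2Cl)OC1c1cccnc1` gives 42 nM; the step of a 1.1-fold lower number from compound 1 to compound 2 (0.06 log units; within the scatter) lies within the scatter. Compound 3 `O=C(O)CC/C=C\CC1COC(c2ccsc2)OC1c1cccnc1` gives 500 nM and stands highest of the three numbers, with compound 1 nearest and compound 2 furthest. The two steps that lead to it, a 10-fold higher number from compound 1 to compound 3 (1.02 log units; beyond the scatter) and a 12-fold higher number from compound 2 to compound 3 (1.08 log units; beyond the scatter), are both large, and both put a thiophen-3-yl group in place of 2-chlorophenyl or 2,4-dichlorophenyl on the saturated ring carbon.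

Compound 4 `CC(C)(Sc1ccccc1)C1OCC(C/C=C\CCC(=O)O)C(c2cccnc2)O1` has not yet been measured. It differs from compound 3 in one place: a group of 10 heavy atoms (9 carbon, 1 sulfur; one six-membered aromatic ring of carbon only) in place of a group of 5 heavy atoms (4 carbon, 1 sulfur; one five-membered aromatic ring with 1 hetero atom), on a saturated ring carbon. The entering group again brings a six-membered aromatic ring of carbon only to that position. The two large steps into compound 3 bear on this change, and both ran upward when such a ring gave way to the thiophen-3-yl group; the reverse exchange is therefore expected to run downward. For the measured compounds named here, since the entering group is not the same as the one that left in compound 1 or compound 2, the size remains uncertain. The estimate for compound 4 is 120 nM, with a range from 30 nM to 500 nM. The step of a 4.2-fold lower number from compound 3 to compound 4 (0.62 log units; beyond the scatter) is expected to lie beyond the scatter.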

Compound 4, half-maximal inhibitory concentration: 40 nM
Compound 4: the middle estimate sits 3.0-fold (0.48 log units) above what was measured; the measured number falls inside the stated range.
By their numbers in this assay, from the lowest: compounds 4, 2 and 1 (each within the scatter of the next); then compound 3.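

In this assay, putting the group of 10 heavy atoms in place of thiophen-3-yl, on the saturated ring carbon between two ring oxygen atoms, gives a large step (a 13-fold lower number from compound 3 to compound 4 (1.10 log units; beyond the scatter)). Set against the two chlorinated compounds, the same group gives steps within the scatter (a 1.1-fold lower number from compound 2 to compound 4 (0.02 log units; within the scatter); a 1.2-fold lower number from compound 1 to compound 4 (0.08 log units; within the scatter)), so compound 4, compound 2 and compound 1 cannot be told apart in this assay, and only compound 3 stands apart from them. The earlier compounds shown here offered only 2-chlorophenyl, 2,4-dichlorophenyl and thiophen-3-yl at this position; compound 4 adds that a group of 10 heavy atoms with a six-membered aromatic ring of carbon only and no chlorine sits level with the 2-chlorophenyl and 2,4-dichlorophenyl groups.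

Nothing available explains why thiophen-3-yl stands apart or why the entering group matches the chlorinated ones. The compounds shown leave open whether the sulfur atom of the entering group matters, since none here carries an ether oxygen or a methylene in its place, and whether an amine or a methoxy group on its aromatic ring would hold the number where it stands.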